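A few compounds are considered here, and "the series" means these few. Any claim that something is new, unique, unknown or untested is made for them only; others in the source may bear on it.

Measured in a functional assay on A549 cells (Homo sapiens) for inhibition, read by sulforhodamine B assay; on this read-out higher numbers stand for weaker inhibition of growth and lower numbers for stronger inhibition of growth
Compound 1 `COc1ccc(-c2ccc(-c3ccc(-c4nc5cc(C)ccc5[nH]4)cc3)cc2)cc1OC` gives 2100 nM
Compound 2 `COc1cc(-c2ccc(-c3ccc(-c4nc5cc(C)ccc5[nH]4)cc3)cc2)cc(OC)c1OC` gives < 100 nM
Compound 3 `COc1ccc(-c2ccc(-c3ccc(-c4nc5ccccc5[nH]4)cc3)cc2)cc1OC` gives 7600 nM

Of the two exact numbers, compound 1 holds the lower one. The entry for compound 2 is a limit, not an exact number.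

Compound 4 `Cc1ccc2[nH]c(-c3ccc(-c4ccc(-c5ccc(F)cc5)cc4)cc3)nc2c1` keeps the core of compound 1 and has 4-fluorophenyl in place of 3,4-dimethoxyphenyl on an aromatic carbon. The most relevant evidence concerns this same group. Adding one more methoxy to it gave a large step, an at least 21-fold lower number from compound 1 to compound 2 (1.32 log units; beyond the scatter), and compound 4 moves the opposite way by carrying no methoxy, so a higher number is expected in this assay. The other measured step, a 3.6-fold higher number from compound 1 to compound 3 (0.56 log units; beyond the scatter), is modest and concerns a methyl on the core, so it bears little on this change. Within the data shown here, no measured step shows what the fluorine does alone, so the expected size stays uncertain. The expected change is modest, a 2.4-fold higher number from compound 1 to compound 4 (0.38 log units; beyond the scatter), with a wide margin. For compound 4 the estimated value is 5000 nM, within an expected range of 1000 nM to 20000 nM.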

Compound 4, concentration for 50% growth inhibition: 6030 nM
Beside the measured number, compound 4's estimate is 1.2-fold (0.08 log units) below it; the range from low to high includes it.
By their numbers in this assay, from the lowest: compound 1; then compounds 4 and 3 (each within the scatter of the next). At a limit, below all of these: compound 2.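

In this assay, replacing 3,4-dimethoxyphenyl with 4-fluorophenyl gives a 2.9-fold higher number from compound 1 to compound 4 (0.46 log units; beyond the scatter), so removing both methoxy groups and adding fluorine weakens growth inhibition only modestly. The earlier compounds shown here showed only what adding a methoxy to this ring does, whereas this result shows that the same position also responds when the methoxy groups are lost, with a much smaller step than the large one seen on adding a methoxy. The value for compound 2 remains a limit, not an exact number: the limit of < 100 nM in this assay, at which 1 of the 4 values shown sits.

These compounds cannot separate the effect of losing the methoxy groups from that of gaining the fluorine, since the swap makes both changes at once. A plain phenyl ring, or a ring carrying an amine or a carboxylic acid at this place, would show how far the response at this position extends.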